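Aryl Replacement on the Urea Nitrogen of the Shared Core

The source may hold more compounds than are shown below. What is called first, only, known or untested is meant among the compounds shown, and "the series" means these compounds.

Measured compounds:
compound 1 `O=C(Nc1ccccc1F)N1CCN(c2ccnc(Cl)n2)CC1`: in an assay on isolated protein for antagonist activity at transient receptor potential cation channel subfamily V member 1 (Homo sapiens) (a lower number here means a stronger inhibitor, a higher number a weaker inhibitor), compound 1 gives 787 nM
compound 2 `O=C(Nc1ccccc1C(F)(F)F)N1CCN(c2ccnc(Cl)n2)CC1`: in this assay compound 2 gives 136 nM

Compound 1 holds the highest number of the two; its nearest neighbour is compound 2, with a 5.8-fold lower number from compound 1 to compound 2 (0.76 log units; beyond the scatter). Compound 3 `O=C(Nc1ccc(Cl)cc1)N1CCN(c2ccnc(Cl)n2)CC1` carries 4-chlorophenyl in place of 2-fluorophenyl on an amide-type nitrogen. For the measured compounds named here, the only measured step, from compound 1 to compound 2, swaps one group for another at the same place; no measured pair exchanges the aryl group as a whole, so that step bears on the present change only loosely. Compound 3 is therefore expected to land near compound 1, with an estimated step of a 1.7-fold lower number from compound 1 to compound 3 (0.24 log units; within the scatter) and a wide range: estimated 450 nM, between 90 nM and 2200 nM.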

Compound 3, half-maximal inhibitory concentration: 1250 nM
Compound 3: the middle estimate sits 2.8-fold (0.44 log units) below what was measured; the measured number falls inside the stated range.
By their numbers in this assay, from the lowest: compound 2; then compounds 1 and 3 (each within the scatter of the next).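

In this assay, exchanging the whole aryl group on the amide-type nitrogen gives a 1.6-fold higher number from compound 1 to compound 3 (0.20 log units; within the scatter) and so does not separate 4-chlorophenyl from 2-fluorophenyl. Unlike the earlier trifluoromethyl-for-fluoro step, this exchange leaves the number at this position unresolved from that of compound 1. Nothing available here accounts for this result.

Still open, on these data alone, is whether the lower number of compound 2 depends on the trifluoromethyl group alone or carries over to other aryl groups. Also open, as far as these compounds go, is how a phenyl ring bearing a nitrile or a carboxylic acid would read in this assay on the shared core.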